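Swapping the aryl on the triazole of a spiro-fused core

The source may hold more compounds than are shown below. What is called first, only, known or untested is meant among the compounds shown, and "the series" means these compounds.

Of the compounds shown here, three sharing one spiro-fused core have been tested in a functional assay on MCF7 cells (Homo sapiens) for antiproliferative activity, read by MTT assay, with a stated time of 48 h; a lower number here means a stronger inhibitor, a higher number a weaker inhibitor. Compound 1 `COc1ccc(-n2nncc2CN2C(=O)C3(C(C#N)=C(N)Oc4c3c3nc5ccccc5nc3c3ccccc43)c3ccccc32)cc1` carries a 4-methoxyphenyl on the triazole. In this assay compound 1 reaches only the limit > 50000 nM, which is a limit and not a number. Compound 2 `N#CC1=C(N)Oc2c(c3nc4ccccc4nc3c3ccccc23)C12C(=O)N(Cc1cnnn1-c1ccc(N)cc1)c1ccccc12` differs by amino in place of methoxy on an aromatic carbon. In this assay compound 2 likewise reaches only the limit > 50000 nM. The step that the two limits leave unreadable from compound 1 to compound 2 therefore cannot be read, since the limit of > 50000 nM in this assay, at which 2 of the 3 values shown sit, is where both values sit. Compound 3 `N#CC1=C(N)Oc2c(N)cc3nc4ccccc4nc3c2C12C(=O)N(Cc1cnnn1-c1cccc(C(F)(F)F)c1)c1ccccc12` has an amino on the fused ring system and a 3-(trifluoromethyl)phenyl on the triazole. In this assay, for the measured compounds named here, compound 3 gives 31600 nM, the only value in the set that is a number rather than a limit.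

Compound 4 `N#CC1=C(N)Oc2c(N)cc3nc4ccccc4nc3c2C12C(=O)N(Cc1cnnn1-c1c(F)cccc1F)c1ccccc12` differs from compound 3 by 2,6-difluorophenyl in place of 3-(trifluoromethyl)phenyl on an aromatic nitrogen. Going by the values given here, none of the measured steps touches this position, so no measured step bears on the change. With no guidance either way, no step beyond the usual scatter is expected, and the expected step of no change at the digits printed from compound 3 to compound 4 (within the scatter) is set close to zero. Compound 4 is therefore expected to give 31600 nM, with a range from 12000 nM to 80000 nM.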

Compound 4, half-maximal inhibitory concentration: > 50000 nM
Compound 4 was reported as a limit; the forecaster's own chance of this, stated with the estimate: 35%; middle value at least 1.5-fold (0.19 log units) away from the limit.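

Replacing 3-(trifluoromethyl)phenyl with 2,6-difluorophenyl on the aromatic nitrogen of the triazole gives, in this assay, an at least 1.5-fold higher number from compound 3 to compound 4 (0.19 log units; that floor lies within the scatter). The result for compound 4 is a limit and not a number, so this step has a floor but no measured size, and with that floor inside the scatter it does not establish that the swap makes the compound a weaker inhibitor. Unlike the step between compound 1 and compound 2, which cannot be read, this is the first change at this position with a number on one side, and it shows that the single numerical result does not survive this swap, leaving most of the set at one limit: the limit of > 50000 nM in this assay, at which 3 of the 4 values shown sit.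

The compounds shown leave open whether any group on this aromatic nitrogen would give a clearly lower number in this assay, for example an unsubstituted phenyl, a benzyl or a phenyl carrying a carboxylic acid. They also leave open what the amino on the fused ring system contributes, since compound 3 differs from compound 1 and compound 2 in more than one place.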